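The compounds below may be only part of what the source reports. "The series", "measured", "known", "first", "only" and "open" are said of these compounds alone.

Working notes on an ADME assay on microsomes from liver (Mus musculus) for metabolic stability, read by mass spectrometry, with a stated time of 40 min, tested at 1 uM; a higher number here means that more of the compound is left, a lower number that less of the compound is left. Compound 3 (`COc1cc(N2CCN(CC3CCOC3)CC2)ccc1Nc1nc(NC2CCCCC2)c2nc[nH]c2n1`) gives 59%, within the scatter of compound 1 (`COc1cc(N2CCN(C(=O)C3CCC(O)CC3)CC2)ccc1Nc1nc(NC2CCCCC2)c2nc[nH]c2n1`) at 68%, while compound 2 (`COc1cc(N2CCN(C(=O)N3CCN(C)CC3)CC2)ccc1Nc1nc(NC2CCCCC2)c2nc[nH]c2n1`) gives 46%. Compound 4 (`CCN(CC)CC1CCN(c2ccc(Nc3nc(NC4CCCCC4)c4nc[nH]c4n3)c(OC)c2)CC1`) differs from compound 3 as follows: 4-((diethylamino)methyl)piperidin-1-yl in place of 4-((oxolan-3-yl)methyl)piperazin-1-yl on an aromatic carbon. Among the measured compounds shown here, no measured step makes this exchange, so the evidence is indirect. The steps bearing on it are a number 22 percentage points lower from compound 1 to compound 2 (beyond the scatter), a number 9 percentage points lower from compound 1 to compound 3 (within the scatter) and a number 13 percentage points higher from compound 2 to compound 3 (beyond the scatter), all changes within the same substituent and none larger than modest. A modest fall is tentatively expected, guided by compound 2 at 46%, giving an expected a number 14 percentage points lower from compound 3 to compound 4 (beyond the scatter). Compound 4 is estimated at 45%, with an expected range of 25% to 62%.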

Compound 4, percent of the compound remaining: 47%
Estimate against measurement, compound 4: 2 percentage points below, within the range that was stated.
By their numbers in this assay, from the lowest: compounds 2 and 4 (each within the scatter of the next); then compounds 3 and 1 (each within the scatter of the next).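

In this assay, among the compounds shown here, replacing the ring on the aromatic carbon for the first time, with 4-((diethylamino)methyl)piperidin-1-yl entering, gives a number 12 percentage points lower from compound 3 to compound 4 (beyond the scatter). Both groups have 12 heavy atoms, so at this position equal heavy-atom count does not give an equivalent number. No measurement available here accounts for the step.

The exchange alters the ring and its side chain together, leaving open which part goes with the lower number. A piperidin-1-yl ring bearing (oxolan-3-yl)methyl, or a piperazin-1-yl ring bearing a diethylaminoethyl chain, would help separate the two.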